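The source may hold more compounds than are shown below. What is called first, only, known or untested is meant among the compounds shown, and "the series" means these compounds.

Measured compounds in an assay on liver for inhibition of sterol O-acyltransferase 1 (Rattus norvegicus), using microsomes; on this read-out higher numbers stand for weaker inhibition and lower numbers for stronger inhibition:
- compound 1 `CC(C)c1cccc(C(C)C)c1OC(=O)NS(=O)(=O)N1CCCCC1` gives > 100000 nM, which is a limit of the assay and not a number.
- compound 2 `CC(C)c1cccc(C(C)C)c1OC(=O)NS(=O)(=O)N(C(C)C)C(C)C` gives 15000 nM.
- compound 3 `CC(C)c1cccc(C(C)C)c1OC(=O)NS(=O)(=O)Nc1ccccc1` gives 38100 nM.

Compound 3 stands highest of the two numbers in this assay; the nearest is compound 2, with the step of a 2.5-fold higher number from compound 2 to compound 3 (0.40 log units; beyond the scatter). Within the data shown here, the only other measured value is the limit of compound 1 (the limit of > 100000 nM in this assay, at which 1 of the 3 values shown sits), so the steps of an at least 6.6-fold lower number from compound 1 to compound 2 (0.82 log units; beyond the scatter) and an at least 2.6-fold lower number from compound 1 to compound 3 (0.41 log units; beyond the scatter) are known only as lower bounds.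

Compound 4 `CC(C)c1cccc(C(C)C)c1OC(=O)NS(=O)(=O)Oc1c(F)cccc1F` differs from compound 3 in one place: 2,6-difluorophenoxy in place of anilino on a sulfonyl sulfur. Among the measured compounds shown here, all three measured steps exchange the group on this same sulfonyl sulfur, and each is modest or at least modest; none of them swaps an amino group for an aryloxy group, so no measured step maps onto this change directly. The measured steps show that different groups at this position spread the numbers over a modest span. The expectation for compound 4 is therefore a step of a 1.5-fold lower number from compound 3 to compound 4 (0.18 log units; within the scatter) of modest size, direction uncertain, leaning towards a lower number. Compound 4 is estimated at 25000 nM, with a range from 6000 nM to 100000 nM.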

Compound 4, half-maximal inhibitory concentration: 38000 nM
Compound 4: the middle estimate sits 1.5-fold (0.18 log units) below what was measured, within the range that was stated.
By their numbers in this assay, from the lowest: compound 2; then compounds 4 and 3 (each within the scatter of the next). At a limit, above all of these: compound 1.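

Replacing anilino, which carries a hydrogen-bond donor, with 2,6-difluorophenoxy, which carries none, gives a 1.0-fold lower number from compound 3 to compound 4 (0.00 log units; within the scatter) in this assay, so at this pair the amide-type link and its donor can be exchanged for an aryloxy group with no change beyond the scatter. Against diisopropylamino, the same aryloxy group gives a 2.5-fold higher number from compound 2 to compound 4 (0.40 log units; beyond the scatter), which leaves compound 2 with the lowest number of the measured compounds. The step of an at least 2.6-fold lower number from compound 1 to compound 4 (0.42 log units; beyond the scatter) is only a lower bound, because the value of compound 1 is a limit and not a number: the limit of > 100000 nM in this assay, at which 1 of the 4 values shown sits.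

From the compounds shown here alone, whether the fluorine atoms of 2,6-difluorophenoxy contribute anything stays open, and plain phenoxy would separate them from the oxygen link. Also open, going by these compounds, is whether a longer chain on this sulfonyl sulfur, such as dodecylamino, moves the number outside the span seen so far.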